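Bromo replaces methylsulfonyl on the phenyl of compound 3

This account rests on a few compounds, and the source may have more. Where it says the series, first, only, none or still open, it means among the compounds named here.

Measured so far in a functional assay on CHO cells for antagonist activity at metabotropic glutamate receptor 5 (Rattus norvegicus), read by FLIPR and calcium flux; on this read-out lower numbers stand for stronger inhibition and higher numbers for weaker inhibition:
compound 1 `Cc1ccc2cnc(-c3ccccc3)nc2n1` — 2700 nM
compound 2 `COc1ccccc1-c1ncc2ccc(C)nc2n1` — > 30000 nM
compound 3 `Cc1ccc2cnc(-c3cccc(S(C)(=O)=O)c3)nc2n1` — > 30000 nM

Compound 1 carries an unsubstituted phenyl on the shared core and is the only one of the three with a measured number. Compound 2 gives in this assay > 30000 nM, which is a limit of the assay and not a number. Compound 3 likewise gives in this assay > 30000 nM, again a limit and not a number, so it sits at the weak end of what is shown, together with compound 2, at the limit of > 30000 nM in this assay, at which 2 of the 3 values shown sit.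

The step to the unmeasured compound 4 `Cc1ccc2cnc(-c3cccc(Br)c3)nc2n1` is bromo in place of methylsulfonyl on an aromatic carbon.

For the measured compounds named here, two measured steps bear on it, both starting from compound 1: an at least 11-fold higher number from compound 1 to compound 2 (1.04 log units; beyond the scatter) and an at least 11-fold higher number from compound 1 to compound 3 (1.04 log units; beyond the scatter). Both attach a group to the phenyl and both push the number onto the limit. The present change runs the other way, removing the methylsulfonyl and leaving only a single-atom bromo. The step is therefore expected to be large and downward: an at least 25-fold lower number from compound 3 to compound 4 (1.39 log units; beyond the scatter). Compound 4 is estimated at 1200 nM, within 250 nM to 12000 nM, near the region of compound 1, though a further limit cannot be excluded.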

Compound 4, half-maximal inhibitory concentration: 38 nM
Beside the measured number, compound 4's estimate is 32-fold (1.50 log units) above it, outside the stated range (below it).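

In this assay, a group on the phenyl no longer means only a loss: bromo in place of hydrogen gives a 71-fold lower number from compound 1 to compound 4 (1.85 log units; beyond the scatter), whereas the methoxy of compound 2 and the methylsulfonyl of compound 3 had each brought the number up to the limit of the assay. On these data alone, the same aromatic carbon therefore tolerates one group and not another, and the exchange of methylsulfonyl for bromo, which removes both hydrogen-bond acceptors of the leaving group, gives an at least 780-fold lower number from compound 3 to compound 4 (2.89 log units; beyond the scatter), a step whose true size remains unknown and can only be larger. The value of compound 3 is a limit and not a number, and it stands at the weak end of the series: the limit of > 30000 nM in this assay, at which 2 of the 4 values shown sit.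

The compounds shown do not tell whether bromo is special at this place or whether chloro, methyl or a nitrile there would lower the number as far. They also leave open how bromo would behave elsewhere on the phenyl, and whether an amine or a longer chain could be carried at this same carbon.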